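Moving the halogen around on the sulfonyl-linked phenyl ring

The source may hold more compounds than are shown below. What is called first, only, known or untested is meant among the compounds shown, and "the series" means these compounds.

Compounds measured so far in an assay on isolated protein for inhibition of kallikrein-7 (Mus musculus), read by fluorescence, with stated times of 10 min and 30 min; a lower number here means a stronger inhibitor, a higher number a weaker inhibitor:
compound 1, `CC1=NC(c2cn(S(=O)(=O)c3ccc(F)cc3)c3ccc(C)cc23)CN1`: > 30000 nM, a limit of the assay rather than a number
compound 2, `CC1=NC(c2cn(S(=O)(=O)c3cccc(Cl)c3)c3ccc(C)cc23)CN1`: 10000 nM
compound 3, `CC1=NC(c2cn(S(=O)(=O)c3ccccc3Br)c3ccc(C)cc23)CN1`: 400 nM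

Compound 1 thus stands at the weak end, sitting at the limit of > 30000 nM in this assay, at which 1 of the 3 values shown sits, while compound 2 and compound 3 give real numbers. Compound 4, `CC1=NC(c2cn(S(=O)(=O)c3c(Cl)cccc3Cl)c3ccc(C)cc23)CN1`, is not yet measured; it differs from compound 1 by 2,6-dichlorophenyl in place of 4-fluorophenyl on a sulfonyl sulfur. For the measured compounds named here, three measured steps bear on this change: an at least 3.0-fold lower number from compound 1 to compound 2 (0.47 log units; beyond the scatter), an at least 75-fold lower number from compound 1 to compound 3 (1.87 log units; beyond the scatter) and a 25-fold lower number from compound 2 to compound 3 (1.40 log units; beyond the scatter). In where its halogens sit, 2,6-dichlorophenyl resembles 2-bromophenyl more than 3-chlorophenyl or 4-fluorophenyl, so a large drop in this assay is expected, about an at least 50-fold lower number from compound 1 to compound 4 (1.69 log units; beyond the scatter). Compound 4 is therefore estimated at 600 nM, between 100 nM and 4000 nM.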

Compound 4, half-maximal inhibitory concentration: 10000 nM
Compound 4: middle estimate off by 17-fold (1.22 log units), on the low side; the measured number lies above the stated range.
By their numbers in this assay, from the lowest: compound 3; then compounds 2 and 4 (each within the scatter of the next). At a limit, above all of these: compound 1.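

In this assay, 2,6-dichlorophenyl on the sulfonyl sulfur does not keep the gain seen with 2-bromophenyl: the result is a 25-fold higher number from compound 3 to compound 4 (1.40 log units; beyond the scatter), and there is no change at the digits printed from compound 2 to compound 4 (within the scatter), so that gain does not simply carry over to another halogenated phenyl. Against 4-fluorophenyl, the change still gives an at least 3.0-fold lower number from compound 1 to compound 4 (0.47 log units; beyond the scatter). That size is only a minimum, as compound 1 stands at a limit rather than a number: the limit of > 30000 nM in this assay, at which 1 of the 4 values shown sits.

The compounds shown cannot tell whether the strength of compound 3 goes with bromine itself or with carrying one halogen rather than two. Plain phenyl, 2-chlorophenyl and a ring bearing an amine lie outside this set.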